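This account rests on a few compounds, and the source may have more. Where it says the series, first, only, none or still open, it means among the compounds named here.

Going by the values given here, compound 1 `COc1cc(Nc2nc3ccccc3nc2S(=O)(=O)c2ccccc2)cc(OC)c1` is the stronger of the two measured members in a functional assay on PC-3 cells (Homo sapiens) for cytotoxicity, read by MTT assay, with a stated time of 72 h; a higher number here means a weaker inhibitor, a lower number a stronger inhibitor: compound 1 gives 140 nM, whereas compound 2 `COc1cc(Nc2nc3ccccc3nc2S(=O)(=O)c2ccccc2)cc(OC)c1OC` gives 29100 nM, a step of a 210-fold higher number from compound 1 to compound 2 (2.32 log units; beyond the scatter). Compound 3 `O=S(=O)(c1ccccc1)c1nc2ccccc2nc1Nc1ccc(F)cc1` is the untested analogue, differing from compound 1 by 4-fluorophenyl in place of 3,5-dimethoxyphenyl on a nitrogen on an aromatic ring. Among the compounds with values here, no measured step exchanges this aryl group outright; the single step, from compound 1 to compound 2, only shows that the shared core responds strongly to substitution on that ring, so a weakening of some size is expected in this assay. Compound 3 is estimated at 1500 nM (range 200 nM to 12000 nM), an expected step of an 11-fold higher number from compound 1 to compound 3 (1.03 log units; beyond the scatter).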

Compound 3, half-maximal inhibitory concentration: 14200 nM
The estimate for compound 3 lay 9.5-fold (0.98 log units) below the measured number; measured number above the stated range.
By their numbers in this assay, from the lowest: compound 1; then compound 3; then compound 2.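

In this assay, exchanging the whole aryl group on the nitrogen gives a 100-fold higher number from compound 1 to compound 3 (2.01 log units; beyond the scatter), so a large loss at this position is not confined to adding a methoxy. Among the aryl groups compared here, 3,5-dimethoxyphenyl gives the lower number, and 4-fluorophenyl does not replace it. Nothing measured explains this loss. Still open, on these data alone, is whether a plain phenyl or a ring bearing a single methoxy would keep the number of compound 1. Also open, as far as these compounds go, is how an amine or a carboxylic acid on this ring would behave.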